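A few compounds are considered here, and "the series" means these few. Any claim that something is new, unique, unknown or untested is made for them only; others in the source may bear on it.

Measured so far in an ADME assay on HELF cells (Homo sapiens) for cytotoxicity, with a stated time of 3 days; a higher number here means that more compound is tolerated, a lower number that less compound is tolerated:

Compound 1, `CC(C)CNC(=O)[C@H](C)NC(=O)[C@]1(Cc2ccccc2)CCN1C(=O)OCc1ccccc1`: compound 1 gives > 100000 nM, a limit of the assay and not a number.
Compound 2, `C[C@H](NC(=O)[C@]1(Cc2ccccc2)CCN1C(=O)OCc1ccccc1)C(=O)NC(C)(C)C`: compound 2 gives > 100000 nM, again a limit of the assay.
Compound 3, `CC(C)[C@H](NC(=O)[C@@]1(Cc2ccccc2)CCN1C(=O)OCc1ccccc1)C(N)=O`: compound 3 gives > 100000 nM, also a limit of the assay.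

Compound 3 therefore stands only at a limit in this assay; the two further values shown for this assay are limits as well. Among the measured compounds shown here, the one measured step between compounds that differ in one place, a step that the two limits leave unreadable from compound 1 to compound 2, is left unreadable by the two limits, and the change there, tert-butyl in place of isobutyl on an amide-type nitrogen, is of a different kind from the one now followed.

The next compound is compound 4, `CC(C)[C@H](NC(=O)[C@]1(Cc2ccccc2)CCN1C(=O)OCc1ccccc1)C(N)=O`. Its difference from compound 3: the two compounds have the same atoms and bonds and differ only in configuration as drawn: 1 of 2 stereo elements differ; a stereocentre at a saturated ring carbon is drawn R in compound 3 and S in compound 4.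

For the measured compounds named here, no measured step bears on a change of configuration at that ring carbon. What the numbers offer is the limit of > 100000 nM in this assay, at which 3 of the 3 values shown sit, so the working expectation is that compound 4 will also sit at the limit in this assay and that no step beyond the scatter will be seen. The estimated step that the limit leaves unreadable from compound 3 to compound 4 is therefore expected to be none beyond the scatter. For compound 4 the estimate in this assay is 150000 nM, in the range 50000 nM to 500000 nM.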

Compound 4, minimum cytotoxic concentration: > 100000 nM
Compound 4: no number, only a limit; the forecaster's own chance of this, stated with the estimate: 85%; the middle value lies beyond the limit too.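

Compound 4 gives > 100000 nM in this assay, a limit of the assay and not a number. No step from compound 1, compound 2 or compound 3 to compound 4 can be read: the limit of > 100000 nM in this assay, at which 4 of the 4 values shown sit.

The compounds shown leave open whether the configuration at the saturated ring carbon makes any difference to the concentration tolerated in this assay.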